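Cyclohexyl Out, Chlorophenyl In on the Shared Core

A few compounds are considered here, and "the series" means these few. Any claim that something is new, unique, unknown or untested is made for them only; others in the source may bear on it.

Measured compounds:
compound 1 `O=C1C(Nc2ccccc2)=CC(=O)c2c1nc1n2[C@H]2OC[C@@H](O)[C@H]2OC1`: > 8000 nM
compound 2 `O=C1C(Nc2ccc(Br)cc2)=CC(=O)c2c1nc1n2[C@H]2OC[C@@H](O)[C@H]2OC1`: 5220 nM
compound 3 `O=C1C=C(NC2CCCCC2)C(=O)c2c1nc1n2[C@H]2OC[C@@H](O)[C@H]2OC1`: > 16000 nM

In a functional assay on HeLa cells (Homo sapiens) for inhibition, read by sulforhodamine B assay (a higher number here means a weaker inhibitor, a lower number a stronger inhibitor), compound 3 gives > 16000 nM, which is a limit of the assay and not a number, so it sits among the weakest values shown (the limit of > 16000 nM in this assay, at which 1 of the 3 values shown sits). Compound 4 `O=C1C=C(Nc2cccc(Cl)c2)C(=O)c2c1nc1n2[C@H]2OC[C@@H](O)[C@H]2OC1` differs from it in one place: 3-chlorophenyl in place of cyclohexyl on an amine nitrogen. Among the compounds with values here, no measured step matches this change exactly. The closest guide is an at least 1.5-fold lower number from compound 1 to compound 2 (0.18 log units; that floor lies within the scatter), a small step that stays within the scatter. Compound 1 sits at a limit there (the limit of > 8000 nM in this assay, at which 1 of the 3 values shown sits). Compound 2, with a halogen on its phenyl, gives 5220 nM, a measurable number. A halogen-bearing phenyl on the amine nitrogen is thus the only aryl that produced a number. Compound 4 is expected to give a measurable value too, the step of an at least 2.2-fold lower number from compound 3 to compound 4 (0.35 log units; beyond the scatter), with an estimate of 7000 nM and a range from 3000 nM to 20000 nM.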

Compound 4, half-maximal inhibitory concentration: 6040 nM
Beside the measured number, compound 4's estimate is 1.2-fold (0.06 log units) above it; measured number inside the range.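

In this assay, compound 3 gives > 16000 nM, which is a limit of the assay and not a number. Swapping cyclohexyl for 3-chlorophenyl on this amine nitrogen gives an at least 2.6-fold lower number from compound 3 to compound 4 (0.42 log units; beyond the scatter), showing that this change can move the result by more than ordinary scatter. Its full size stays unknown because the starting point is a limit: the limit of > 16000 nM in this assay, at which 1 of the 4 values shown sits.

As far as these compounds go, what a plain phenyl or a hexyl chain would give on this same nitrogen remains open. The step therefore cannot yet be divided between the aromatic ring and the chlorine.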